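The source may report more compounds than this note shows. Statements on the series, on what has been measured and on what is new or still open speak of the compounds shown alone.

Measured so far in a physicochemical assay for solubility, using the shake flask method, measured as kinetic solubility, with a stated time of 2 h, at pH 7.4 (on this read-out lower numbers stand for lower solubility and higher numbers for higher solubility), are two compounds.
Compound 1 `CN(Cc1ccc(C(F)(F)F)cc1)c1cc(C(=O)Nc2ccccc2)ncn1` gives < 5000 nM.
Compound 2 `COc1ccc(NC(=O)c2cc(N(C)Cc3cccc(F)c3)ncn2)cc1` gives 5000 nM.

Compound 1 has the reading < 5000 nM, which is a limit of the assay and not a number. Its place on the scale is therefore the limit of < 5000 nM in this assay, at which 1 of the 2 values shown sits, and nothing finer.

Compound 3 `CN(Cc1ccc(C#N)cc1)c1cc(C(=O)Nc2ccccc2)ncn1` keeps the core of compound 1 and alters one group, with cyano in place of trifluoromethyl on an aromatic carbon. Counted out, the change is cyano in place of trifluoromethyl on an aromatic carbon and the rest of the structure stays as it was.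

For the measured compounds named here, no two measured compounds differ in just one place, so there is no measured step to lean on. The expectation in this assay is therefore for no change beyond the usual scatter, with the direction left open. The estimated size is a number no lower from compound 1 to compound 3 (the limit leaves the size open) and it is only a rough expectation.

Compound 2 gives 5000 nM as a plain number, which makes a value in that region a fair expectation for compound 3.

A reading that is only a limit is quite possible for compound 3.

The expected value for compound 3 is 5000 nM within an estimated range of 2000 nM to 20000 nM for repeat measurements.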

Compound 3, solubility: < 5000 nM
Compound 3 gave a limit, no number (the forecaster's own chance of this, stated with the estimate: 50%); the middle value lies on the limit itself.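

In this assay, compound 1 and compound 3 each give only a limit of the assay and not a number, so no step can be read for cyano in place of trifluoromethyl: the limit of < 5000 nM in this assay, at which 2 of the 3 values shown sit. The compounds shown leave open where the true solubility of compound 1 and compound 3 lies, and whether the two differ at all.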